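From Methoxy to Ethyl in a Small Series

The compounds below may be only part of what the source reports. "The series", "measured", "known", "first", "only" and "open" are said of these compounds alone.

In a functional assay on MCF7 cells (Homo sapiens) for antiproliferative activity, with a stated time of 5 days (on this read-out lower numbers stand for stronger inhibition and higher numbers for weaker inhibition), compound 1 (`COc1ccc(-c2[nH]c3ccc(F)cc3c2C=O)cc1`) gives 240 nM while compound 2 (`CCCCc1ccc2[nH]c(-c3ccc(OC)cc3)c(C=O)c2c1`) gives 22 nM and compound 3 (`CCCCCCc1ccc2[nH]c(-c3ccc(OC)cc3)c(C=O)c2c1`) gives 6 nM as the third number. Compound 2 is thus the second highest of the three. Compound 4 (`CCCCc1ccc2[nH]c(-c3ccc(CC)cc3)c(C=O)c2c1`) has ethyl in place of methoxy on an aromatic carbon. The series shows large steps of an 11-fold lower number from compound 1 to compound 2 (1.04 log units; beyond the scatter) and a 40-fold lower number from compound 1 to compound 3 (1.60 log units; beyond the scatter) and a modest step of a 3.7-fold lower number from compound 2 to compound 3 (0.56 log units; beyond the scatter) in all. Among the measured compounds shown here, each exchanges fluoro, butyl or hexyl, and none touches the methoxy, so no measured step bears directly on this change. A small rise in this assay is expected, possibly within the scatter. The expected step is a 1.5-fold higher number from compound 2 to compound 4 (0.16 log units; within the scatter) by this estimate. Compound 4 is estimated at 32 nM with an expected range of 9 nM to 110 nM overall.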

Compound 4, half-maximal inhibitory concentration: 58 nM
For compound 4 the middle estimate is 1.8-fold (0.26 log units) below the measured one, within the range that was stated.
By their numbers in this assay, from the lowest: compound 3; then compound 2; then compound 4; then compound 1.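

Among the compounds shown here, the methoxy group had not been varied in the earlier compounds, and in this assay ethyl in its place gives a 2.6-fold higher number from compound 2 to compound 4 (0.42 log units; beyond the scatter), so this position on the six-membered aromatic ring is not indifferent to the change. The exchange keeps the heavy-atom count the same while losing the one hydrogen-bond acceptor, so the step comes from a swap of equal size. No measurement shown accounts for this step. From the compounds shown here alone, it remains open how a hydroxyl, an amine or a longer chain would fare here, and whether ethyl in place of methoxy would give a similar step on the hexyl compound 3.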